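Ethynyl in place of thiophen-2-yl on a limit-bound compound

The source may report more compounds than this note shows. Statements on the series, on what has been measured and on what is new or still open speak of the compounds shown alone.

In a functional assay on HepG2 cells (Homo sapiens) for antiproliferative activity, read by XTT assay, with a stated time of 72 h (a higher number here means a weaker inhibitor, a lower number a stronger inhibitor), compound 3 (`COc1nc(N)nc2c1c(-c1cccs1)cn2[C@@H]1O[C@H](CO)[C@@H](O)[C@H]1O`) gives only a limit, > 20000 nM, and no number. Compound 2 (`Nc1nc(N)c2c(-c3cccs3)cn([C@@H]3O[C@H](CO)[C@@H](O)[C@H]3O)c2n1`) also gives only a limit, > 20000 nM, and no number. For the measured compounds named here, that leaves a step that the two limits leave unreadable from compound 2 to compound 3 as the only measured step, and it offers no size to carry over. Compound 4 (`C#Cc1cn([C@@H]2O[C@H](CO)[C@@H](O)[C@H]2O)c2nc(N)nc(OC)c12`) comes from compound 3 by ethynyl in place of thiophen-2-yl on an aromatic carbon, with ethynyl in place of thiophen-2-yl on an aromatic carbon. Compound 1 (`C#Cc1cn([C@@H]2O[C@H](CO)[C@@H](O)[C@H]2O)c2ncnc(OC)c12`) also carries ethynyl, though its core differs, and gives 12700 nM as a measured number, so a modest move towards stronger inhibition is expected. The estimated change is an at least 1.8-fold lower number from compound 3 to compound 4 (0.25 log units; that floor lies within the scatter) in this assay. Compound 4 is expected near 11000 nM, with an estimated range from 3000 nM to 20000 nM in this assay.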

Compound 4, half-maximal inhibitory concentration: > 20000 nM
Compound 4 gave a limit, no number (the forecaster's own chance of this, stated with the estimate: 35%); middle value at least 1.8-fold (0.25 log units) from the limit.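

Ethynyl in place of thiophen-2-yl on this aromatic carbon still leaves compound 4 at a limit in this assay, so ethynyl alone does not bring a measurable number on this amino-bearing core. Neither this step nor the earlier one can be read, because each compares two compounds at the same limit: the limit of > 20000 nM in this assay, at which 3 of the 4 values shown sit. Amino in place of hydrogen gives an at least 1.5-fold higher number from compound 1 to compound 4 (0.19 log units; that floor lies within the scatter).

On these data alone, whether thiophen-2-yl on the core of compound 1 would give a number remains open. So does the effect of an amine or a propyl chain on this carbon of that core.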